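The source may report more compounds than this note shows. Statements on the series, on what has been measured and on what is new or still open speak of the compounds shown alone.

In a physicochemical assay for solubility (on this read-out higher numbers stand for higher solubility and lower numbers for lower solubility), compound 3 (`O=C(CCCc1ccccc1)n1c(=S)oc2ccccc21`) gives 100000 nM and so stands level with compound 1 (`CCCCCCCCCC(=O)n1c(=S)oc2ccccc21`) at 100000 nM and within the scatter of compound 2 (`CCCCCC(=O)n1c(=O)oc2ccccc21`) at 150000 nM on the same read-out. Going on to compound 4 (`CCCCCC(=O)n1c(=S)oc2ccccc21`) puts ethyl in place of phenyl on a saturated chain carbon, three bonds along the chain from a carbonyl carbon. Among the compounds with values here, one measured step bears on this place, phenyl in place of hexyl (no change at the digits printed from compound 1 to compound 3 (within the scatter)), and it stayed within the scatter. No step beyond the scatter is therefore expected in this assay for this exchange. The estimated step (a 1.1-fold higher number from compound 3 to compound 4 (0.04 log units; within the scatter)) lies within the scatter. Compound 4 is expected at 110000 nM with an estimated range of 65000 nM to 180000 nM on this read-out.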

Compound 4, solubility: 130000 nM
Beside the measured number, compound 4's estimate is 1.2-fold (0.07 log units) below it; the measured number falls inside the stated range.
By their numbers in this assay, from the lowest: compounds 1, 3, 4 and 2 (each within the scatter of the next).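

In this assay, ethyl in place of phenyl on a saturated chain carbon, three bonds along the chain from a carbonyl carbon, gives a 1.3-fold higher number from compound 3 to compound 4 (0.11 log units; within the scatter) and so shows that the aromatic ring can leave this place without a step beyond the scatter. Hydrogen in place of butyl, five bonds along the chain from a carbonyl carbon, gives a 1.3-fold higher number from compound 1 to compound 4 (0.11 log units; within the scatter) and so also stays within the scatter. No measured evidence accounts for either step. Going by these compounds, whether an amine or a carboxylic acid at this place, or a longer chain than that of compound 1, would also stay within the scatter remains open.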